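Methyl for methoxy on the biaryl of compound 1

The source may report more compounds than this note shows. Statements on the series, on what has been measured and on what is new or still open speak of the compounds shown alone.

Measured compounds, with their values in a physicochemical assay for lipophilicity, read by HPLC, at pH 7.5; on this read-out higher numbers stand for higher lipophilicity and lower numbers for lower lipophilicity:
- compound 1, `CC[C@@H](Nc1c(C#N)c(-c2ccc(-c3cccc(OC)c3)cc2)nc2cnccc12)C(N)=O`: compound 1 gives 2.7
- compound 2, `CCOc1ccccc1-c1ccc(-c2nc3cnccc3cc2C#N)cc1`: compound 2 gives 3.8
- compound 3, `CCOc1ccccc1-c1ccc(-c2nc3cnccc3c(N[C@H](CC)C(=O)NS(C)(=O)=O)c2C#N)cc1`: compound 3 gives 2.2

Compound 1 stands second highest of the three numbers in this assay, with compound 3 nearest and compound 2 furthest. For the measured compounds named here, the one step between compounds that differ in a single place is a number 1.60 log units lower from compound 2 to compound 3 (beyond the scatter); it concerns a larger group entering on the shared core and has no bearing on the change considered here.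

Compound 4, `CC[C@@H](Nc1c(C#N)c(-c2ccc(-c3cccc(C)c3)cc2)nc2cnccc12)C(N)=O`, differs from compound 1 by methyl in place of methoxy on an aromatic carbon. Going by the values given here, no measured pair covers a methoxy-to-methyl exchange, so the expectation rests on the single-point change alone and carries a wide range. The step is expected to be a small rise, a number 0.50 log units higher from compound 1 to compound 4 (beyond the scatter), still close to the scatter. Compound 4 is therefore estimated at 3.2, with a range from 2.8 to 3.6.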

Compound 4, distribution coefficient: 3
Compound 4: the middle estimate sits 0.20 log units above what was measured; measured number inside the range.
By their numbers in this assay, from the lowest: compound 3; then compounds 1 and 4 (each within the scatter of the next); then compound 2.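

In this assay, exchanging 3-methoxyphenyl for 3-methylphenyl gives a step that cannot be told from repeat measurement (a number 0.30 log units higher from compound 1 to compound 4 (within the scatter)), so at this place, on an aromatic carbon meta to a large group, methoxy and methyl are not separated by this read-out. For the compounds shown here, this is the first pair to isolate a change at this place, and the only earlier step (a number 1.60 log units lower from compound 2 to compound 3 (beyond the scatter)) concerns a much larger group entering on the shared core, so it says nothing about this position. No available measurement offers an explanation for this result.

On these data alone, whether other groups at this place, such as an amine or a carboxylic acid, would also leave the read-out within the scatter remains open. Also open, as far as these compounds go, is whether the methoxy-to-methyl exchange would read the same with a different chain on the shared core.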